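Changing the Aryl Group on the Ring Nitrogen

The compounds below may be only part of what the source reports. "The series", "measured", "known", "first", "only" and "open" are said of these compounds alone.

Three compounds have been measured in a functional assay on 143B cells (Homo sapiens) for inhibition, read by CCK-8 assay, with a stated time of 72 h, tested at 1 uM; a higher number here means more inhibition at the concentration tested (going by the name of the read-out), a lower number less inhibition:
compound 1, `COc1ccc(OC)c(N2C(=O)CSC2c2cccc(C(=O)NCCCCc3ccccc3)c2)c1`, gives 2%;
compound 2, `COc1ccc(F)cc1N1C(=O)CSC1c1cccc(C(=O)NCCCCc2ccccc2)c1`, gives 62%;
compound 3, `Cc1cccc(N2C(=O)CSC2c2cccc(C(=O)NCCCCc3ccccc3)c2)c1`, gives 71%.

Compound 3 and compound 2 lie within the scatter of each other, a number 9 percentage points higher from compound 2 to compound 3 (within the scatter), while compound 1 lies far below both, a number 69 percentage points higher from compound 1 to compound 3 (beyond the scatter) and a number 60 percentage points higher from compound 1 to compound 2 (beyond the scatter). Compound 4, `COc1cccc(OC)c1N1C(=O)CSC1c1cccc(C(=O)NCCCCc2ccccc2)c1`, differs from compound 3 in one place: 2,6-dimethoxyphenyl in place of 3-methylphenyl on an amide-type nitrogen in a ring. For the measured compounds named here, the step that bears on this is the one from compound 1 to compound 3, which was large and upward; compound 4 reverses that kind of change, although its two methoxy groups sit differently from those of compound 1. A large downward step, a number 46 percentage points lower from compound 3 to compound 4 (beyond the scatter), is therefore expected, with wide uncertainty. Compound 4 is estimated at 25%, between 0% and 65%.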

Compound 4, a percentage reported as inhibition, at one concentration (the size of the read-out at that concentration, not a potency): 31%
Compound 4: the middle estimate sits 6 percentage points below what was measured; the range from low to high includes it.
By their numbers in this assay, from the lowest: compound 1; then compound 4; then compounds 2 and 3 (each within the scatter of the next).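

In this assay, 2,6-dimethoxyphenyl on the amide-type nitrogen in the ring falls short of 3-methylphenyl, a number 40 percentage points lower from compound 3 to compound 4 (beyond the scatter), and of 5-fluoro-2-methoxyphenyl, a number 31 percentage points lower from compound 2 to compound 4 (beyond the scatter). Yet it keeps more inhibition than 2,5-dimethoxyphenyl, a number 29 percentage points higher from compound 1 to compound 4 (beyond the scatter), so at this position the arrangement of two methoxy groups matters, not only their presence. Nothing available explains this difference. The compounds shown leave open whether an amine or a carboxylic acid on this aryl ring would keep the inhibition. They also leave open how a shorter chain on the amide would fare with each aryl group.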